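The compounds below may be only part of what the source reports. "The series", "measured", "known", "first", "only" and "open" are said of these compounds alone.

The measured compounds:

Compound 1, `CC(=O)N1CCc2nc(C#Cc3ccccc3)sc2C1`, in an assay on HEK293 cells for negative allosteric modulation of metabotropic glutamate receptor 5 (Homo sapiens), read by FLIPR, with a stated time of 1 h (a lower number here means a stronger inhibitor, a higher number a weaker inhibitor), gives 90 nM.
Compound 2, `CCC(=O)N1CCc2nc(C#Cc3ccccc3)sc2C1`, in this assay gives 38 nM.
Compound 3, `O=C(C1CCC(F)(F)CC1)N1CCc2nc(C#Cc3ccccc3)sc2C1`, in this assay reaches only the limit > 10000 nM, so no number is known for it.

Compound 3 therefore stands at the top of the range shown, at the limit of > 10000 nM in this assay, at which 1 of the 3 values shown sits, whereas compounds 1 and 2 sit far lower. Compound 4, `O=C(C1CCOCC1)N1CCc2nc(C#Cc3ccccc3)sc2C1`, is not yet measured; it differs from compound 3 in one place: oxan-4-yl in place of 4,4-difluorocyclohexyl on a carbonyl carbon.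

Among the measured compounds shown here, the steps that bear on this change are those that brought the six-membered ring onto the carbonyl carbon: an at least 110-fold higher number from compound 1 to compound 3 (2.04 log units; beyond the scatter) and an at least 260-fold higher number from compound 2 to compound 3 (2.42 log units; beyond the scatter). Both show that a ring of this size on the carbonyl carbon, in place of a short chain, costs a large amount in this assay. Compound 4 keeps a six-membered ring in the same place, so a number close to that of compound 3, possibly again only a limit, is expected; because an at least 110-fold higher number from compound 1 to compound 3 (2.04 log units; beyond the scatter) was so large, only a modest recovery is anticipated from the smaller ring with its one acceptor. Compound 4 is thus expected to give about 6000 nM, within 1200 nM to 30000 nM, a step of an at least 1.6-fold lower number from compound 3 to compound 4 (0.22 log units; that floor lies within the scatter).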

Compound 4, half-maximal inhibitory concentration: > 10000 nM
Compound 4: a limit, no number; the forecaster's own chance of this, stated with the estimate: 40%; middle value at least 1.6-fold (0.22 log units) from the limit.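

Compound 4 in this assay stops at the same limit as compound 3, and this is a limit, not a number: the limit of > 10000 nM in this assay, at which 2 of the 4 values shown sit.

The large loss on the carbonyl carbon is therefore not tied to 4,4-difluorocyclohexyl, since oxan-4-yl, a six-membered ring with 1 hetero atom and 1 hydrogen-bond acceptor, also gives an at least 110-fold higher number from compound 1 to compound 4 (2.04 log units; beyond the scatter) when it replaces methyl, and an at least 260-fold higher number from compound 2 to compound 4 (2.42 log units; beyond the scatter) when it replaces ethyl. The step between compound 3 and compound 4 cannot be read, so any difference between the two rings stays hidden, and the oxygen of oxan-4-yl brings no recovery that this assay can show.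

The compounds shown leave open where, between ethyl and these six-membered rings, the number begins to climb. A longer chain such as butyl, or a cyclopropyl ring, on the carbonyl carbon would bear on that.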